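Removing the Second Silyl Group from a Nucleoside Urea

The compounds below may be only part of what the source reports. "The series", "measured", "known", "first", "only" and "open" are said of these compounds alone.

Within the data shown here, compound 2 `Cc1cn([C@@H]2O[C@H](CO)[C@@]3(OS(=O)(=O)C=C3NC(=O)NC(=O)c3ccccc3)[C@H]2O[Si](C)(C)C(C)(C)C)c(=O)n(C)c1=O` gives 16000 nM in an ADME assay on HEL cells (Homo sapiens) for cytotoxicity, with a stated time of 3 days (a higher number here means that more compound is tolerated, a lower number that less compound is tolerated), and is the only plain number in this set. Compound 1 `Cc1cn([C@@H]2O[C@H](CO[Si](C)(C)C(C)(C)C)[C@@]3(OS(=O)(=O)C=C3NC(=O)NC(=O)c3ccccc3)[C@H]2O[Si](C)(C)C(C)(C)C)c(=O)n(C)c1=O` reaches only the limit of > 200000 nM in this assay. Compound 3 `Cc1cn([C@@H]2O[C@H](CO)[C@@]3(OS(=O)(=O)C=C3NC(=O)NC(=O)c3ccccc3)[C@H]2O)c(=O)n(C)c1=O` differs from compound 2 by a hydrogen atom in place of a group of 7 heavy atoms (6 carbon, 1 silicon; no ring), on an oxygen on a saturated carbon. Among the measured compounds shown here, the one measured step of the same kind, an at least 12-fold lower number from compound 1 to compound 2 (1.09 log units; beyond the scatter), is the only guide, and it rests partly on a limit (the limit of > 200000 nM in this assay, at which 1 of the 2 values shown sits), so its true size is uncertain. This second removal is therefore expected to shift the number only modestly, estimated as a 1.6-fold higher number from compound 2 to compound 3 (0.19 log units; within the scatter). Compound 3 is estimated at 25000 nM, within a range from 4000 nM to 150000 nM.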

Compound 3, half-maximal cytotoxic concentration: > 50000 nM
Compound 3 was reported as a limit; the forecaster's own chance of this, stated with the estimate: 20%; at least 2.0-fold (0.30 log units) between middle value and limit.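

In this assay, replacing the silicon-bearing group of 7 heavy atoms with hydrogen at this oxygen gives an at least 3.1-fold higher number from compound 2 to compound 3 (0.49 log units; beyond the scatter), so more compound is tolerated. The same kind of swap at a different oxygen gave an at least 12-fold lower number from compound 1 to compound 2 (1.09 log units; beyond the scatter), so in these compounds the direction of the change depends on where it is made. Compound 3 gives > 50000 nM, which is a limit, so the full size of its step cannot be read.

From the compounds shown here alone, what a methyl or an acetyl group on this oxygen would do to the number remains open.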